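The source may report more compounds than this note shows. Statements on the series, on what has been measured and on what is new or still open speak of the compounds shown alone.

Working notes on the series. Compound 2 `O=C(Nc1cccc(Cl)c1)N1CCc2[nH]nc(-c3ccccc3)c2C1` and compound 1 `O=C(Nc1ccccc1Cl)N1CCc2[nH]nc(-c3ccccc3)c2C1` share one core and differ only in the chlorophenyl on the urea-type nitrogen. In a physicochemical assay for solubility, at pH 7 (on this read-out higher numbers stand for higher solubility and lower numbers for lower solubility), compound 2 gives 20000 nM, and compound 1 gives 18000 nM; the step of a 1.1-fold higher number from compound 1 to compound 2 (0.05 log units; within the scatter) is within the scatter, so neither compound is set apart from the other on this read-out. Compound 3 `C[C@@H]1Cc2[nH]nc(-c3ccccc3)c2CN1C(=O)Nc1cccc(Cl)c1` keeps the 3-chlorophenyl of compound 2 and adds (methyl in place of hydrogen on a saturated ring carbon). Going by the values given here, no measured step touches this position, and the one step available concerns a different part of the molecule. For compound 3 the expected step of a 1.4-fold lower number from compound 2 to compound 3 (0.15 log units; within the scatter) is therefore set within the scatter, and compound 3 is estimated at 14000 nM with a range of 6000 nM to 35000 nM.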

Compound 3, solubility: 20000 nM
For compound 3 the middle estimate is 1.4-fold (0.15 log units) below the measured one, and the stated range covers the measured number.
By their numbers in this assay, from the lowest: compounds 1, 2 and 3 (each within the scatter of the next).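

In this assay, going by these compounds alone, methyl in place of hydrogen on a saturated ring carbon gives no change at the digits printed from compound 2 to compound 3 (within the scatter), the first reading at this position, since the earlier pair differs only in the chlorophenyl. This position therefore takes a methyl with no step beyond the scatter, at least with the 3-chlorophenyl in place. Nothing at hand bears on the reason for this result. Still open, as far as these compounds go, is whether a longer chain, an amine or a carboxylic acid on this ring carbon would leave the number equally unmoved. Also open, from the compounds shown here alone, is whether the methyl gives the same reading alongside the 2-chlorophenyl of compound 1.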